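The compounds below may be only part of what the source reports. "The series", "measured", "known", "first", "only" and "open" are said of these compounds alone.

Series notes, measured in a functional assay on CHO cells for antagonist activity at prostaglandin E2 receptor EP4 subtype (Homo sapiens), read by calcium flux, with a stated time of 15 min; a higher number here means a weaker inhibitor, a lower number a stronger inhibitor:

Compound 1, `C[C@H](NC(=O)c1c(C(F)(F)F)nnn1Cc1ccc(F)cc1)c1ccc(C(=O)O)cc1`: 2320 nM
Compound 2, `C[C@H](NC(=O)c1cnnn1Cc1ccc(C(F)(F)F)cc1)c1ccc(C(=O)O)cc1`: > 10000 nM (a limit)

Compound 2 stands at the edge of what this assay can report. For compound 2 the value > 10000 nM is a limit of the assay and not a number, and it is the only such entry here (the limit of > 10000 nM in this assay, at which 1 of the 2 values shown sits). Among the measured compounds shown here, compound 1, which carries a trifluoromethyl on the five-membered ring and a 4-fluorobenzyl, is the only compound with a measured number, at 2320 nM; it differs from compound 2 in two places, so no single step connects the two, and their values show only that one is within range and the other is not.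

Compound 3, `C[C@H](NC(=O)c1c(C2CCCCC2)nnn1Cc1ccc(C(F)(F)F)cc1)c1ccc(C(=O)O)cc1`, is compound 2 with cyclohexyl in place of hydrogen on an aromatic carbon. For the measured compounds named here, no measured step covers a change of this kind, so the expectation rests on the one measured number and the one limit. Compound 3 is expected to move into the measurable range, with a step from compound 2 to compound 3 of an at least 6.6-fold lower number from compound 2 to compound 3 (0.82 log units; beyond the scatter) in this assay, although a second limit cannot be excluded. For compound 3 the estimate is 1500 nM, in the range 300 nM to 8000 nM.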

Compound 3, half-maximal inhibitory concentration: 161 nM
Compound 3: middle estimate off by 9.3-fold (0.97 log units), on the high side; measured number below the stated range.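

Placing cyclohexyl in place of hydrogen on this aromatic carbon of the five-membered aromatic ring gives an at least 62-fold lower number from compound 2 to compound 3 (1.79 log units; beyond the scatter) in this assay. Among the compounds shown here, this is the only single-place step so far, and it shows that, with the 4-(trifluoromethyl)benzyl group held constant, the substituent on this carbon alone can separate a compound at the assay limit from one with a measured number, and that a six-membered non-aromatic ring of carbon only is tolerated here. The true size of the step remains unknown because the entry for compound 2 is a limit and not a number: the limit of > 10000 nM in this assay, at which 1 of the 3 values shown sits.

From the compounds shown here alone, whether this result requires a ring of this size, or would also follow from a methyl, a phenyl or an amine on the same carbon, remains open. Compound 1 differs from compound 3 in two places, so the trifluoromethyl and cyclohexyl groups on this carbon cannot be compared directly, and the contribution of the benzyl substituent cannot be separated from theirs.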